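The compounds below may be only part of what the source reports. "The series", "measured", "known", "first", "only" and "open" are said of these compounds alone.

Compound 1 `COc1cccc(-c2nc(SC)nc3sc(C(=O)NCc4ccccc4)c(N)c23)c1` gives 3% in a functional assay on HEK293 cells for agonist activity at Thyrotropin receptor (Homo sapiens), read by cAMP accumulation; a higher number here means a larger maximal response, a lower number a smaller maximal response.
Compound 2 `COc1cccc(-c2nc(SC)nc3sc(C(=O)NCCO)c(N)c23)c1` gives 2.9% in this assay.
Compound 3 `CCNC(=O)c1sc2nc(SC)nc(-c3cccc(OC)c3)c2c1N` gives 2.3% in this assay.

Among these three numbers, compound 1 holds the largest one, but only just: the step of a number 0.1 percentage points lower from compound 1 to compound 2 (within the scatter) and the step of a number 0.7 percentage points lower from compound 1 to compound 3 (within the scatter) both sit inside the usual scatter, so the three compounds cannot be told apart by this read-out. All three show very little maximal response.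

Compound 4 `COc1cccc(-c2nc(SC)nc3sc(C(=O)NNC(=O)OC(C)(C)C)c(N)c23)c1` differs from compound 1 in one place: (tert-butoxycarbonyl)amino in place of benzyl on an amide-type nitrogen. The steps already measured bear directly on this position. Exchanging the group on the amide-type nitrogen gave a number 0.1 percentage points lower from compound 1 to compound 2 (within the scatter) and a number 0.7 percentage points lower from compound 1 to compound 3 (within the scatter), and the further exchange a number 0.6 percentage points lower from compound 2 to compound 3 (within the scatter) was likewise inside the scatter. Going by the values given here, nothing so far suggests that the substituent on this nitrogen moves the response. For compound 4 the expected step is therefore no change at the digits printed from compound 1 to compound 4 (within the scatter), that is, none beyond the scatter. Compound 4 is estimated at 3%, with a range from 0% to 12%.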

Compound 4, largest response reached (reported as efficacy), in percent of the reference or control that the assay uses: 1.9%
For compound 4 the middle estimate is 1.1 percentage points above the measured one, and the stated range covers the measured number.
By their numbers in this assay, from the lowest: compounds 4, 3, 2 and 1 (each within the scatter of the next).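

Even an exchange this large on the amide-type nitrogen gives compounds that this assay cannot tell apart: (tert-butoxycarbonyl)amino in place of benzyl gives a number 1.1 percentage points lower from compound 1 to compound 4 (within the scatter), in place of ethyl it gives a number 0.4 percentage points lower from compound 3 to compound 4 (within the scatter), and in place of 2-hydroxyethyl it gives a number 1 percentage points lower from compound 2 to compound 4 (within the scatter). The earlier compounds shown here all kept a saturated carbon chain on this nitrogen, whereas here a further nitrogen stands on it, the six-membered aromatic ring is gone, and a hydrogen-bond donor and hydrogen-bond acceptors enter, yet no step leaves the scatter. No measurement shown explains this flat picture.

As far as these compounds go, whether a carboxylic acid, or a longer chain ending in an amine, on this nitrogen would give a response clear of the scatter stays open. So does whether a change elsewhere on the shared core would.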